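The source may report more compounds than this note shows. Statements on the series, on what has been measured and on what is new or still open speak of the compounds shown alone.

Measured in a functional assay for inhibition, read by spectrophotometry, with a stated time of 20 min, tested at 2 mg/mL; on this read-out lower numbers stand for a weaker effect and higher numbers for a stronger effect at the one concentration tested:
compound 1, `CC(=O)c1ccc(NC(=O)C(C(C)C)N(C(=O)c2ccccc2)S(=O)(=O)c2ccc(C)cc2)cc1`, gives 22.7%;
compound 2, `CC(=O)c1ccc(NC(=O)C2CC(O)CN2S(=O)(=O)c2ccc(C)cc2)cc1`, gives 12.5%;
compound 3, `CC(=O)c1ccc(NC(=O)C(C(C)C)N(C(=O)c2ccccc2)S(=O)(=O)c2ccc([N+](=O)[O-])cc2)cc1`, gives 29.8%.

Compound 3 differs from compound 1 in one place only, by nitro in place of methyl on an aromatic carbon, and the measured step is a number 7.1 percentage points higher from compound 1 to compound 3 (within the scatter). Compound 2 has a different core from compound 1; how the two cores differ is not broken down here. Compound 4, `CC(=O)c1ccc(NC(=O)C2CC(O)CN2S(=O)(=O)c2ccc([N+](=O)[O-])cc2)cc1`, has not yet been measured. It differs from compound 2 by nitro in place of methyl on an aromatic carbon, which is the same change, made at the same place, as that from compound 1 to compound 3. The step from compound 2 to compound 4 is expected to be a number 7 percentage points higher from compound 2 to compound 4 (within the scatter), of about the size of the earlier step, because the earlier step of a number 7.1 percentage points higher from compound 1 to compound 3 (within the scatter) was small. Compound 4 is therefore estimated at 19.5%, most likely between 8% and 32%.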

Compound 4, a percentage reported as inhibition, at one concentration (the size of the read-out at that concentration, not a potency): 57%
For compound 4 the middle estimate is 37.5 percentage points below the measured one, outside the stated range (above it).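

In this assay, the change from 4-methylphenyl to 4-nitrophenyl gives a number 44.5 percentage points higher from compound 2 to compound 4 (beyond the scatter). The same change therefore does not have a fixed size in this series, and its size on one core is a poor guide to its size on another: the same change on two cores in this assay, a number 7.1 percentage points higher (within the scatter) from compound 1 to compound 3 and a number 44.5 percentage points higher (beyond the scatter) from compound 2 to compound 4, 37.4 percentage points apart, beyond the scatter of two such steps

Going by these compounds alone, with only two cores and one concentration, this does not show why the size differs or which part of the cores matters. The compounds shown leave open whether an amine or a carboxylic acid in place of the methyl would also give a large step on the core of compound 2, and whether either would give a small step on the core of compound 1.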